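Replacing a chlorobenzyl amide with a cyclohexyl amide

The compounds below may be only part of what the source reports. "The series", "measured", "known", "first", "only" and "open" are said of these compounds alone.

Of the compounds shown here, three built on one shared core have been tested in a functional assay on A549 cells (Homo sapiens) for cytotoxicity, read by MTT assay, with a stated time of 24 h; on this read-out higher numbers stand for weaker inhibition and lower numbers for stronger inhibition. Compound 1 `C=CC1=C(C(=O)NCc2ccc(Cl)cc2)C(c2ccc(OC)c(OC)c2)OC1` carries a 4-chlorobenzyl group on its amide nitrogen. In this assay compound 1 gives only a limit, > 100000 nM, and no number. Compound 2 `C=CC1=C(C(=O)NCCCCC)C(c2ccc(OC)cc2)OC1` gives 36500 nM in this assay. Compound 3 `C=CC1=C(C(=O)Nc2cccc(C)c2)C(c2ccc(F)cc2)OC1` likewise gives only a limit in this assay, > 100000 nM. Among the compounds with values here, compound 1 therefore stands at the limit of > 100000 nM in this assay, at which 2 of the 3 values shown sit, a place it shares with compound 3, while compound 2 is the single compound with a measured number.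

Compound 4 `C=CC1=C(C(=O)NC2CCCCC2)C(c2ccc(OC)c(OC)c2)OC1` differs from compound 1 in one place: cyclohexyl in place of 4-chlorobenzyl on an amide-type nitrogen. Within the data shown here, no measured pair shows this change, so nothing among the three compounds points to a direction for it. Since compound 1 sits at the limit, only a move toward stronger inhibition could appear as a change; a step within the usual scatter is the plainest expectation. The expected step in this assay is an at least 1.4-fold lower number from compound 1 to compound 4 (0.15 log units; that floor lies within the scatter), a small move at most. For compound 4 the estimated value in this assay is 70000 nM, within a range from 25000 nM to 150000 nM, and it remains well possible that compound 4 again returns only a limit.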

Compound 4, half-maximal inhibitory concentration: > 100000 nM
Compound 4: only a limit was reported; the forecaster's own chance of this, stated with the estimate: 55%; middle value at least 1.4-fold (0.15 log units) away from the limit.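

Compound 1 and compound 4 each return only a limit in this assay and no number, so no step can be read between them: the limit of > 100000 nM in this assay, at which 3 of the 4 values shown sit.

The compounds shown leave open whether cyclohexyl in place of 4-chlorobenzyl on an amide-type nitrogen changes the result at all, and in which direction.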